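From 4-methoxyphenyl to 2-bromophenyl on the carbonyl carbon

This account rests on a few compounds, and the source may have more. Where it says the series, first, only, none or still open, it means among the compounds named here.

In a functional assay on MCF7 cells (Homo sapiens) for inhibition, read by MTT assay, with a stated time of 24 h (a lower number here means a stronger inhibitor of growth, a higher number a weaker inhibitor of growth), compound 1 (`COc1ccccc1C(=O)n1c(-c2cn(C)c3ccccc23)nc2ccccc21`) gives 32100 nM and compound 2 (`COc1ccc(C(=O)n2c(-c3cn(C)c4ccccc34)nc3ccccc32)cc1`) gives 16300 nM. For the measured compounds named here, these are the only two numbers so far, and they lie within the scatter of each other, so compound 2 cannot be ranked against compound 1. Both sit in the same range of this assay.

The next compound to be measured is compound 3 (`Cn1cc(-c2nc3ccccc3n2C(=O)c2ccccc2Br)c2ccccc21`). The structural change is 2-bromophenyl in place of 4-methoxyphenyl on a carbonyl carbon, with the shared core left as it is. Going by the values given here, the group named 2-methoxyphenyl in compound 1 carries the same number in its name as the incoming 2-bromophenyl, but no measured compound contains bromine, and no measured step covers this exchange directly.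

Among the compounds with values here, the only guide is a 2.0-fold lower number from compound 1 to compound 2 (0.29 log units; within the scatter), a change at the same carbonyl carbon that stays within the scatter. On that single step, no change beyond the scatter is expected in this assay, in either direction, and the expected step is a 1.2-fold higher number from compound 2 to compound 3 (0.09 log units; within the scatter). Compound 3 is estimated at 20000 nM, with an expected range of 8000 nM to 50000 nM.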

Compound 3, concentration for 50% growth inhibition: 70100 nM
Estimate against measurement, compound 3: 3.5-fold (0.54 log units) below, outside the stated range (above it).
By their numbers in this assay, from the lowest: compounds 2 and 1 (each within the scatter of the next); then compound 3.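

In this assay, the carbonyl carbon now shows a change beyond the scatter, which the earlier pair did not: 2-bromophenyl in place of 4-methoxyphenyl gives a 4.3-fold higher number from compound 2 to compound 3 (0.63 log units; beyond the scatter). Bromo in place of methoxy on an aromatic carbon gives a 2.2-fold higher number from compound 1 to compound 3 (0.34 log units; beyond the scatter), so compound 3 stands apart from both methoxy compounds, although both steps are modest and the two methoxy compounds remain unranked against each other. Nothing available on these compounds accounts for either step.

For the compounds shown here, with compound 3 as the only bromine compound, a single exchange cannot show whether the higher number is particular to bromo or would also follow from another group on the same phenyl ring, such as chloro, an amine or a carboxylic acid. Going by these compounds, it also remains open how bromo would read where compound 2 carries its methoxy group, so the separate contributions of the group and its placement on the ring are not yet resolved.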